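Compound 1 and a Trifluoromethyl for Cyano Exchange

The source may hold more compounds than are shown below. What is called first, only, known or untested is meant among the compounds shown, and "the series" means these compounds.

The measured compounds:
- compound 1, `N#Cc1cccc(-c2nc(N)c3cc(CN4CCC(F)CC4)sc3n2)c1`, 2950 nM
- compound 2, `N#Cc1cccc(-c2nc(N)c3cc(CN4CC=CCC4)sc3n2)c1`, 210 nM
- compound 3, `C[C@@H]1CN(Cc2cc3c(N)nc(-c4cccc(C#N)c4)nc3s2)C[C@H](C)O1`, 1070 nM

In an assay on CHO-K1 cells for antagonist activity at adenosine receptor A1 (Homo sapiens), read by a beta-galactosidase reporter, with stated times of 15 min and 6 h (on this read-out lower numbers stand for stronger inhibition and higher numbers for weaker inhibition), compound 1 gives 2950 nM, the highest of the three numbers. Its nearest neighbour is compound 3, which in this assay gives 1070 nM, a change of a 2.8-fold lower number from compound 1 to compound 3 (0.44 log units; beyond the scatter). Further away lies compound 2, which gives 210 nM, with a 14-fold lower number from compound 1 to compound 2 (1.15 log units; beyond the scatter), a large step. Between the two lower compounds the gap is a 5.1-fold higher number from compound 2 to compound 3 (0.71 log units; beyond the scatter).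

Compound 4, `Nc1nc(-c2cccc(C(F)(F)F)c2)nc2sc(CN3CCC(F)CC3)cc12`, differs from compound 1 in one place: trifluoromethyl in place of cyano on an aromatic carbon, on an aromatic carbon of a six-membered aromatic ring of carbon only, meta to a large group. Among the compounds with values here, the three measured steps all concern the group on the saturated chain carbon bound to an aromatic carbon, not the aryl substituent, so none of them bears on this exchange, and nothing among the measured compounds shows how the cyano group contributes. With no guide, a step near the scatter in either direction is the plain expectation, and compound 4 is expected to stay near compound 1 with an estimated step of a 1.2-fold higher number from compound 1 to compound 4 (0.07 log units; within the scatter). The estimate for compound 4 is 3500 nM, with a range from 900 nM to 13000 nM.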

Compound 4, inhibition constant: 3030 nM
For compound 4 the middle estimate is 1.2-fold (0.06 log units) above the measured one; the measured number falls inside the stated range.
By their numbers in this assay, from the lowest: compound 2; then compound 3; then compounds 1 and 4 (each within the scatter of the next).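

In this assay, the exchange of cyano for trifluoromethyl on the aromatic carbon gives a 1.0-fold higher number from compound 1 to compound 4 (0.01 log units; within the scatter), so compound 1 and compound 4 cannot be told apart. Within the data shown here, this is the first reading at this position, and it shows that, with 4-fluoropiperidin-1-yl held constant, a group with more heavy atoms and no hydrogen-bond acceptor can stand in place of cyano without a step beyond the scatter. No measurement at hand accounts for this result.

The compounds shown leave open whether the same exchange would read alike with the lower-number amine groups of compound 2 and compound 3, since this single pair sits at the high end of the series and says nothing about those backgrounds. They also leave open how other groups on this aromatic carbon would read, such as a methoxy group, a chlorine atom, a primary amide or a carboxylic acid, and whether the same groups would behave alike on another carbon of this ring.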